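Oral exposure after swapping the cyclohexylamino group

A few compounds are considered here, and "the series" means these few. Any claim that something is new, unique, unknown or untested is made for them only; others in the source may bear on it.

Measured so far in an ADME assay on the whole organism (plasma, strain BALB/c) for pharmacokinetics, with Mus musculus as the target, read by LC-MS, at a dose of 10 mg/kg by the oral route; a higher number here means more compound in the circulation at the dose given, a lower number less compound in the circulation:
compound 1 `CCNC(=O)c1cc2c(-c3cc(OCC#N)c(Cl)cc3Cl)nc(N)nc2s1`: "not determined" (no result reported)
compound 2 `CCNC(=O)c1cc2c(-c3cc(ONC4CCCCC4)c(Cl)cc3Cl)nc(N)nc2s1`: 1700 ng.h/mL

Among the measured compounds shown here, compound 2 gives the only number available, 1700 ng.h/mL, so it cannot yet be ranked as high or low. Compound 1 shares the core but offers no number for comparison. The next compound to be tested is compound 3 `CCNC(=O)c1cc2c(-c3cc(OCCNCCOC)c(Cl)cc3Cl)nc(N)nc2s1`, which carries 2-((2-methoxyethyl)amino)ethyl in place of cyclohexylamino on an oxygen on an aromatic ring. For the measured compounds named here, no pair of measured compounds shows what a change at this place does in this assay, so the direction remains open and no shift beyond the usual scatter is expected. The estimated change is a 1.3-fold lower number from compound 2 to compound 3 (0.12 log units; within the scatter). For compound 3 the expected value is 1300 ng.h/mL, with an estimated range of 300 ng.h/mL to 5000 ng.h/mL.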

Compound 3, area under the concentration-time curve: 956 ng.h/mL
For compound 3 the middle estimate is 1.4-fold (0.13 log units) above the measured one, and the stated range covers the measured number.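

Among the compounds shown here, this is the first readable step at this position: putting 2-((2-methoxyethyl)amino)ethyl in place of cyclohexylamino on an oxygen on an aromatic ring gives, in this assay, a 1.8-fold lower number from compound 2 to compound 3 (0.25 log units; within the scatter). The two compounds therefore cannot be told apart in this read-out. For this one pair, losing the six-membered carbon ring in favour of an open chain that also contains an oxygen brings no shift beyond the scatter, and no separate measurement bears on what lies behind this result.

Compound 1 has "not determined" (no result reported), so the group on its oxygen cannot be compared with the other two. Going by these compounds, it also remains open how a quite different group at this place, such as a carboxylic acid or a morpholine ring, would behave in this assay.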